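The compounds below may be only part of what the source reports. "The series", "measured", "known", "first", "only" and "open" are said of these compounds alone.

Of the compounds shown here, three sharing one core have been measured in an assay on isolated protein for inhibition of Rho-associated protein kinase 2 (Homo sapiens); on this read-out lower numbers stand for stronger inhibition and higher numbers for weaker inhibition. Compound 1 `CC(C)(C)C[C@H](N)C(=O)Nc1cc2cc[nH]c(=O)c2cc1Cl` gives 845 nM, the second highest of the three numbers. Compound 2 `CN(C)[C@H]1CC[C@@H](C(=O)Nc2cc3cc[nH]c(=O)c3cc2Cl)CC1` gives 1000 nM, and this value lies within the scatter of compound 1. For the measured compounds named here, compound 3 `N[C@H](C(=O)Nc1cc2cc[nH]c(=O)c2cc1Cl)C1CCCCC1` gives 20 nM; the single step between compound 1 and a neighbour that differs in one place, a 42-fold lower number from compound 1 to compound 3 (1.63 log units; beyond the scatter), is large and well beyond the scatter.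

Compound 4 `CC(C)[C@@H](N)C(=O)Nc1cc2cc[nH]c(=O)c2cc1Cl` has not yet been measured. It differs from compound 1 in one place: 1-amino-2-methylpropyl in place of 1-amino-3,3-dimethylbutyl on a carbonyl carbon. Going by the values given here, only the step to compound 3 bears on this change, and it shows that the group on the carbon between the amine nitrogen and the carbonyl carbon can move the number a long way. The entering group is smaller than the cyclohexyl of compound 3, so compound 4 is expected to land between compound 1 and compound 3. Compound 4 is expected to show a 7.0-fold lower number from compound 1 to compound 4 (0.85 log units; beyond the scatter). Compound 4 is therefore estimated at 120 nM, in the range 30 nM to 400 nM.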

Compound 4, half-maximal inhibitory concentration: 240 nM
Compound 4: middle estimate off by 2.0-fold (0.30 log units), on the low side; measured number inside the range.
By their numbers in this assay, from the lowest: compound 3; then compound 4; then compounds 1 and 2 (each within the scatter of the next).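

In this assay, the step of a 3.5-fold lower number from compound 1 to compound 4 (0.55 log units; beyond the scatter) shows that this position responds beyond the scatter even when one open-chain group replaces another, whereas the earlier step at this position brought in a ring. The change is modest beside a 42-fold lower number from compound 1 to compound 3 (1.63 log units; beyond the scatter), and the number falls here as the group goes from 7 heavy atoms to 5, yet heavy-atom count does not order all three compounds: compound 3, with its cyclohexyl group, gives 20 nM, and compound 4 gives 240 nM. No measurement shown offers an explanation for this step.

The compounds leave open how a cyclopentyl or phenyl group would read on the carbon bearing the amine, and whether a straight propyl chain would behave like the branched groups. They also leave open what a methylamine in place of the free amine would do in compound 3.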